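Swapping Nitro for Methyl on Two Related Cores

This account rests on a few compounds, and the source may have more. Where it says the series, first, only, none or still open, it means among the compounds named here.

Measured compounds:
- compound 1, `O=C1NN(c2ccc([N+](=O)[O-])cc2)C(=O)C2(CSC3=C2C(=O)c2ncccc2C3=O)N1`: in a functional assay on HeLa cells (Homo sapiens) for antiproliferative activity, read by MTT assay, with a stated time of 96 h (a higher number here means a weaker inhibitor, a lower number a stronger inhibitor), compound 1 gives 610 nM
- compound 2, `Cc1ccc(N2NC(=O)NC3(CSC4=C3C(=O)c3ncccc3C4=O)C2=O)cc1`: in this assay compound 2 gives 210 nM
- compound 3, `O=C1C2=C(C(=O)c3ncccc31)C1(CS2)NC(=O)N(c2ccc([N+](=O)[O-])cc2)C1=O`: in this assay compound 3 gives 100 nM

Compound 1 and compound 2 share one core and differ in a single group on the aromatic ring, (methyl in place of nitro on an aromatic carbon). That exchange gives a 2.9-fold lower number from compound 1 to compound 2 (0.46 log units; beyond the scatter). Compound 3 carries a different core, and its difference from compound 1 is not broken down here. Among the three measured compounds, compound 3 shows the lowest number in this assay, and its steps to compound 2 and to compound 1 both lie beyond the scatter.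

Compound 4, `Cc1ccc(N2C(=O)NC3(CSC4=C3C(=O)c3ncccc3C4=O)C2=O)cc1`, has not yet been measured. It stands to compound 3 as compound 2 stands to compound 1: methyl in place of nitro on an aromatic carbon. The place of the exchange reads the same in both pairs, so this is the same change, made a second time on the other core. Whether it carries the same weight on the core of compound 3 is not known from the three measurements at hand.

Resting on the step seen from compound 1 to compound 2, the account expects compound 4 to sit below compound 3 by a comparable margin, an expected step of a 2.5-fold lower number from compound 3 to compound 4 (0.40 log units; beyond the scatter). In this assay compound 4 is estimated at 40 nM, with a plausible range from 15 nM to 110 nM.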

Compound 4, half-maximal inhibitory concentration: 2 nM
Beside the measured number, compound 4's estimate is 20-fold (1.30 log units) above it; measured number below the stated range.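

In this assay, the exchange of nitro for methyl on the core of compound 3 gives a 50-fold lower number from compound 3 to compound 4 (1.70 log units; beyond the scatter), so the change lowers the number on both cores, and in each case by more than the scatter. The direction therefore carried over from the core of compound 1 to the core of compound 3, but the size of the step did not: the same change on two cores in this assay, a 2.9-fold lower number (0.46 log units; beyond the scatter) from compound 1 to compound 2 and a 50-fold lower number (1.70 log units; beyond the scatter) from compound 3 to compound 4, 17-fold (1.24 log units) apart, beyond the scatter of two such steps These two pairs show that the step measured on one core was a poor guide to the size of the same step on the other, but they do not explain the gap, and they offer no rule for any further core in this series.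

The compounds shown leave open how other groups at the same place on the aromatic ring would behave on these two cores, for example an amine, a methoxy group or a chlorine atom, and whether the steps would again differ so widely between the cores. They also leave open whether a ring with no group at that place would fall closer to the nitro or to the methyl compounds.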